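Methyl for Cyclopropyl on the Thiophene Ring

The source may hold more compounds than are shown below. What is called first, only, known or untested is meant among the compounds shown, and "the series" means these compounds.

Compound 1 `C[C@H]1[C@H](NCc2ccsc2)C[C@H]2C[C@@H]1C2(C)C` gives 50000 nM in an ADME assay on MDCK cells (Canis lupus familiaris) for cytotoxicity, read by microscopy, with a stated time of 48 h; a lower number here means that less compound is tolerated, a higher number that more compound is tolerated.
Compound 2 `C[C@H]1[C@H](NCc2ccoc2)C[C@H]2C[C@@H]1C2(C)C` gives only a limit in this assay, > 100000 nM.
Compound 3 `C[C@H]1[C@H](NCc2cc(C3CC3)cs2)C[C@H]2C[C@@H]1C2(C)C` gives 25000 nM in this assay.

All three compounds share one saturated core carrying an amine, and differ only in the five-membered aromatic ring attached through a single chain carbon to that amine. Compound 3 stands at the lowest of the two real numbers, but its gap to compound 1 lies within the usual scatter, so no order between them can be claimed. Among the measured compounds shown here, the one measured step, an at least 2.0-fold higher number from compound 1 to compound 2 (0.30 log units; that floor lies within the scatter), swaps the ring itself and ends at the assay's upper limit (the limit of > 100000 nM in this assay, at which 1 of the 3 values shown sits); it says nothing about a substituent on the ring.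

Compound 4 `Cc1csc(CN[C@@H]2C[C@H]3C[C@@H]([C@H]2C)C3(C)C)c1` differs from compound 3 by methyl in place of cyclopropyl on an aromatic carbon. For the measured compounds named here, no measured step touches this position, so the expectation rests on the small size of the change alone, and no shift beyond the scatter is expected: a 1.4-fold higher number from compound 3 to compound 4 (0.15 log units; within the scatter) is the estimated step. Compound 4 is therefore expected to give about 35000 nM in this assay, within 15000 nM to 100000 nM.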

Compound 4, minimum cytotoxic concentration: 12500 nM
For compound 4 the middle estimate is 2.8-fold (0.45 log units) above the measured one, and the stated range ends above it.
By their numbers in this assay, from the lowest: compounds 4, 3 and 1 (each within the scatter of the next, the first and the last beyond it). At a limit, above all of these: compound 2.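

In this assay, the change on this aromatic carbon gives a 2.0-fold lower number from compound 3 to compound 4 (0.30 log units; within the scatter), so cyclopropyl and methyl at this position cannot be told apart. A gap beyond the scatter appears only when compound 4 is set against the unsubstituted thiophene: a 4.0-fold lower number from compound 1 to compound 4 (0.60 log units; beyond the scatter), a step that changes the substituent and the point of attachment of the ring together. Compound 2 gives only a limit, so the remaining step is a floor, an at least 8.0-fold lower number from compound 2 to compound 4 (0.90 log units; beyond the scatter), and its true size is unknown: the limit of > 100000 nM in this assay, at which 1 of the 4 values shown sits.

The compounds shown leave open whether the methyl or the point of attachment accounts for the step from compound 1. They also leave open how this assay would respond to an amine or a carboxylic acid on this aromatic carbon.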